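Swapping a silicon-capped alkyne for a long alkenyl chain

The compounds below may be only part of what the source reports. "The series", "measured", "known", "first", "only" and "open" are said of these compounds alone.

Measured compounds:
- compound 1, `CC(=O)Nc1nc(-c2cccc(NS(=O)(=O)c3ccc(C#CCO)cc3)c2)cs1`: 99.3% in a functional assay on A-375 cells (Homo sapiens) for antiproliferative activity, read by trypan blue exclusion, with a stated time of 48 h, tested at 5 uM; a higher number here means a weaker effect of the compound at the concentration tested, a lower number a stronger effect
- compound 2, `CC(=O)Nc1nc(-c2cccc(NS(=O)(=O)c3ccc(C#C[Si](C)(C)C)cc3)c2)cs1`: 4.2% in this assay
- compound 3, `C#Cc1cccc(S(=O)(=O)Nc2cccc(-c3csc(NC(C)=O)n3)c2)c1`: 29% in this assay

All three share the same core and differ only in the group attached to the six-membered carbon ring of the sulfonamide. Compound 2 gives the lowest number of the three in this assay, and its steps to compound 3 and to compound 1 are both beyond the scatter, so it has the strongest effect in this small set.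

Going by the values given here, the one measured step that bears on the change here is a number 95.1 percentage points lower from compound 1 to compound 2 (beyond the scatter). It shows that the group at this position matters a great deal.

Compound 4, `CCCCCC/C=C\c1ccc(S(=O)(=O)Nc2cccc(-c3csc(NC(C)=O)n3)c2)cc1`, is not yet measured. It differs from compound 2 in this way: a group of 8 heavy atoms (8 carbon; no ring) in place of a group of 6 heavy atoms (5 carbon, 1 silicon; no ring), on an aromatic carbon. The change keeps a carbon-only, ring-free group at the same place but drops the silicon and the triple bond in favour of a longer chain with one double bond.

Among the compounds with values here, there is no measured step that says what the alkenyl chain does, and compound 2 and compound 3 show that two quite different groups here both give low numbers. The expectation for compound 4 is therefore a step of a number 10.8 percentage points higher from compound 2 to compound 4 (beyond the scatter), most likely small, with a wide range. Compound 4 is estimated at 15% in this assay, expected between 3% and 45%.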

Compound 4, a percentage reported as activity, at one concentration (the size of the read-out at that concentration, not a potency): 2.3%
Estimate against measurement, compound 4: 12.7 percentage points above; measured number outside the range, below it.
By their numbers in this assay, from the lowest: compounds 4 and 2 (each within the scatter of the next); then compound 3; then compound 1.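

In this assay, exchanging the silicon-capped alkyne for the long alkenyl chain gives a number 1.9 percentage points lower from compound 2 to compound 4 (within the scatter), so a group of 8 carbon atoms with one double bond matches the group it replaces. The earlier compounds shown here showed that this position is sensitive, and this pair adds that neither the silicon nor the triple bond is required for a low number here. The oxygen-bearing group of compound 1 remains far apart from this new group, with a number 97 percentage points lower from compound 1 to compound 4 (beyond the scatter), although no measurement at hand explains why the two carbon-only groups give such similar numbers or why compound 1 differs so much from them.

The compounds shown leave open how much the length and shape of the chain matter, since a shorter alkenyl chain, a fully saturated chain or the other geometry of the double bond could each be set against compound 4. They also leave open whether a long chain carrying an amine or a carboxylic acid would give a number closer to that of compound 4 or that of compound 1.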